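From cyano to ethoxycarbonyl at the assay limit

The source may report more compounds than this note shows. Statements on the series, on what has been measured and on what is new or still open speak of the compounds shown alone.

Measured in a functional assay on NCI-H727 cells (Homo sapiens) for antiproliferative activity, with a stated time of 48 h (on this read-out lower numbers stand for stronger inhibition and higher numbers for weaker inhibition), each value being a limit:
Compound 1 `COc1ccc(Nc2ccc(-c3ccccc3)nn2)cc1`: > 25000 nM
Compound 2 `CCN(CC)c1ccc(-c2cccc(C#N)c2)nn1`: > 25000 nM
Compound 3 `CCN(CC)c1ccc(-c2ccc(C#N)cc2)nn1`: > 25000 nM

Compound 3 stands at the limit of > 25000 nM in this assay, at which 3 of the 3 values shown sit, so it has no exact value in this assay. Compound 4 `CCOC(=O)c1ccc(-c2ccc(N(CC)CC)nn2)cc1` has ethoxycarbonyl in place of cyano on an aromatic carbon, para to a large group (ethoxycarbonyl in place of cyano on an aromatic carbon). Among the compounds with values here, no step between measured compounds is available as a guide, so no step beyond the scatter is expected in this assay. This expectation rests on compound 3, whose > 25000 nM is a limit. Compound 4 is estimated at 25000 nM, with an expected range from 8000 nM to 50000 nM, and will most likely also be reported as a limit.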

Compound 4, half-maximal inhibitory concentration: 1500 nM
For compound 4 the middle estimate is 17-fold (1.22 log units) above the measured one; measured number below the stated range.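

In this assay, ethoxycarbonyl in place of cyano on an aromatic carbon, para to a large group, brings an at least 16-fold lower number from compound 3 to compound 4 (1.22 log units; beyond the scatter). This shows that the group at this position can move the read-out to a measurable value, which the earlier compounds could not show, as each of them gave only a limit: the limit of > 25000 nM in this assay, at which 3 of the 4 values shown sit.

Going by these compounds, the full size of the step stays open, since the value of compound 3 is only a limit. Also open, on these data alone, is whether a carboxylic acid, an amide or a longer ester chain at this position would act like ethoxycarbonyl.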